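A Nitro Group Returns, Moved Along the Ring

This account rests on a few compounds, and the source may have more. Where it says the series, first, only, none or still open, it means among the compounds named here.

Three related compounds have been measured in a functional assay on CRL2813 cells (Homo sapiens) for cytotoxicity, read by sulforhodamine B assay, with a stated time of 5 days; on this read-out higher numbers stand for weaker inhibition and lower numbers for stronger inhibition. Compound 1 `O=C(Nc1cccc([N+](=O)[O-])c1)N[C@H]1CC[C@H](Oc2ccc(F)cc2)CC1` gives 6700 nM, compound 2 `O=C(Nc1ccccc1F)N[C@H]1CC[C@H](Oc2ccc(F)cc2)CC1` gives 17500 nM, and compound 3 `O=C(Nc1cccc(C(F)(F)F)c1)N[C@H]1CC[C@H](Oc2ccccc2F)CC1` gives 2450 nM. Compound 2 thus carries the highest number of the three, the weakest inhibition here; compound 1 lies nearest to it and compound 3 furthest. The new compound 4 `O=C(Nc1ccc([N+](=O)[O-])cc1)N[C@H]1CC[C@H](Oc2ccc(F)cc2)CC1` differs from compound 2 in one place: 4-nitrophenyl in place of 2-fluorophenyl on an amide-type nitrogen. For the measured compounds named here, only one measured step bears on this swap, a 2.6-fold higher number from compound 1 to compound 2 (0.42 log units; beyond the scatter), in which a nitrophenyl group gave way to 2-fluorophenyl. Bringing a nitrophenyl back, now as 4-nitrophenyl, is expected to lower the number modestly. Compound 4 is therefore estimated at 7000 nM, with a range from 3000 nM to 18000 nM. The expected step is a 2.5-fold lower number from compound 2 to compound 4 (0.40 log units; beyond the scatter).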

Compound 4, half-maximal inhibitory concentration: 2300 nM
Compound 4: middle estimate off by 3.0-fold (0.48 log units), on the high side; the measured number lies below the stated range.
By their numbers in this assay, from the lowest: compounds 4 and 3 (each within the scatter of the next); then compound 1; then compound 2.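

On the amide-type nitrogen, 4-nitrophenyl gives a 7.6-fold lower number from compound 2 to compound 4 (0.88 log units; beyond the scatter) and so outdoes the earlier nitrophenyl step. In this assay the place of the nitro group on the ring also counts, since 4-nitrophenyl in place of 3-nitrophenyl gives a 2.9-fold lower number from compound 1 to compound 4 (0.46 log units; beyond the scatter) and not a change within the scatter. No evidence here explains either step.

Still open, on these data alone, is how far the nitro group itself is needed at this place. A phenyl ring carrying an amine or a carboxylic acid on the same nitrogen would test that.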